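A Longer Chain on Compound 2: What to Expect

A few compounds are considered here, and "the series" means these few. Any claim that something is new, unique, unknown or untested is made for them only; others in the source may bear on it.

Compound 1 `CC(=O)OC[C@H]1O[C@@H](n2cc(-c3cn(Cc4ccc(C(C)(C)C)cc4)nn3)c(=O)[nH]c2=O)C[C@@H]1OC(C)=O`: 94.2%
Compound 2 `CC(=O)OC[C@H]1O[C@@H](n2cc(-c3cc(C)no3)c(=O)[nH]c2=O)C[C@@H]1OC(C)=O`: 90.8%

Both numbers come from a functional assay on NUGC-3 cells (Homo sapiens) for cytotoxicity, read by sulforhodamine B assay, tested at 10 uM; a lower number here means less inhibition, a higher number more inhibition at the concentration tested (going by the name of the read-out). Compound 2 and compound 1 sit close together there, their gap within the usual scatter, so no order can be read between them; both show strong inhibition at the tested concentration.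

Compound 3 `CCCCCc1cc(-c2cn([C@H]3C[C@H](OC(C)=O)[C@@H](COC(C)=O)O3)c(=O)[nH]c2=O)on1` differs from compound 2 in one place: butyl in place of hydrogen on a saturated chain carbon bound to an aromatic carbon.

Among the measured compounds shown here, no step between measured compounds exists to guide this change. Since the measured numbers are already high, the step expected from compound 2 to compound 3 is small, most likely none beyond the scatter: a number 0.2 percentage points higher from compound 2 to compound 3 (within the scatter). Compound 3 is estimated at 91%, within a range from 75% to 98%.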

Compound 3, a percentage reported as inhibition, at one concentration (the size of the read-out at that concentration, not a potency): 91.9%
Compound 3: the middle estimate sits 0.9 percentage points below what was measured; the measured number falls inside the stated range.
By their numbers in this assay, from the lowest: compounds 2, 3 and 1 (each within the scatter of the next).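

Going from the methyl of compound 2 to the pentyl of compound 3 gives, in this assay, a number 1.1 percentage points higher from compound 2 to compound 3 (within the scatter) as the only step available at this position. A butyl added on this saturated chain carbon therefore leaves the two numbers impossible to tell apart, with inhibition still strong. Nothing measured here offers an explanation for this result.
The compounds shown leave open whether a chain ending in an amine or a carboxylic acid on the same carbon would leave the number level. A longer chain, such as decyl, also remains an open case.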